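The compounds below may be only part of what the source reports. "The series", "measured", "known", "first", "only" and "open" are said of these compounds alone.

Measured so far:
- compound 1 `CCCCC(=O)c1c(C)nn(CCCN2CCN(c3ccc(C)cc3)CC2)c(=O)c1N`: 23%
- compound 2 `C=Cc1c(C)nn(CCCN2CCCN(c3ccc(C)cc3)CC2)c(=O)c1N`: 10%
- compound 3 `O=c1occ(-c2ccccc2)n1CCCN1CCN(c2ccc(F)cc2)CC1`: 12%

In a functional assay on the whole organism (Abdomen, strain Swiss) for inhibition, with Mus musculus as the target, with stated times of 30 min, 10 min and 5 min, at a dose of 20 mg/kg by the oral route (a higher number here means a stronger effect of the compound at the dose given, a lower number a weaker effect), compound 3 gives 12%, the second highest of the three numbers. The number of compound 2 lies within the scatter of that of compound 3, so the two cannot be told apart. Compound 1 gives 23%, which stands beyond the scatter above compound 3 and is the furthest of the three from it. Among the measured compounds shown here, no two of the measured compounds differ in a single place, so no measured step is available in this assay.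

Compound 4 `O=c1occ(-c2ccccc2)n1CCCN1CCN(c2cccc(Cl)c2)CC1` differs from compound 3 in one place: 3-chlorophenyl in place of 4-fluorophenyl on an amine nitrogen in a ring. The shared core and the three-carbon chain to the ring nitrogen are unchanged. Nothing in the measured set tests a swap of one halogenated phenyl for another on this ring nitrogen, so no step beyond the scatter is expected in either direction. The step from compound 3 to compound 4 is estimated as a number 1 percentage points higher from compound 3 to compound 4 (within the scatter). Compound 4 is expected to give about 13% in this assay, within 3% to 26%.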

Compound 4, a percentage reported as inhibition, in the whole organism at one dose (the size of the read-out at that dose, not a potency): 31%
Compound 4: the middle estimate sits 18 percentage points below what was measured; the measured number lies above the stated range.
By their numbers in this assay, from the lowest: compounds 2 and 3 (each within the scatter of the next); then compounds 1 and 4 (each within the scatter of the next).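

In this assay, the group on the amine nitrogen of the six-membered ring with two nitrogens is not a silent position: 3-chlorophenyl in place of 4-fluorophenyl gives a number 19 percentage points higher from compound 3 to compound 4 (beyond the scatter) with the shared core and the three-carbon chain unchanged. Among the compounds shown here, this is the first single-place step, and the change moves both the halogen and its place on the phenyl ring while the counts of heavy atoms, donors and acceptors stay the same. Nothing available bears on why this swap alters the read-out.

Left open is whether the chlorine or its place on the phenyl ring carries the step, and 4-chlorophenyl and 3-fluorophenyl on the same nitrogen would separate the two. Also open, from the compounds shown here alone, is how an unsubstituted phenyl or a longer chain to the ring nitrogen would read on this core.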